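This account rests on a few compounds, and the source may have more. Where it says the series, first, only, none or still open, it means among the compounds named here.

Working notes on the series. Within the data shown here, compound 2 `C=CC(=O)Nc1cccc(NC(=O)CSc2nc(Nc3cccc(Cl)c3)c3ccccc3n2)c1` is one of two compounds measured in a functional assay on MGC-803 cells (Homo sapiens) for inhibition, read by MTT assay, with a stated time of 72 h; on this read-out higher numbers stand for weaker inhibition and lower numbers for stronger inhibition; compound 2 gives 7830 nM, and compound 1 `O=C(CSc1nc(Nc2ccccc2)c2ccccc2n1)Nc1ccc(C(F)(F)F)cc1` gives 8670 nM, the two numbers lying within the usual scatter of each other, so no order between them is claimed. Compound 3 `C=CC(=O)Nc1cccc(NC(=O)CSc2nc(Nc3ccc(CC)cc3)c3ccccc3n2)c1` has not been measured; it differs from compound 2 by 4-ethylphenyl in place of 3-chlorophenyl on a nitrogen on an aromatic ring. With no measured step of this kind in the series, the change from compound 2 to compound 3 is expected to move this assay by no more than the scatter, an estimated 1.0-fold higher number from compound 2 to compound 3 (0.01 log units; within the scatter). Compound 3 is thus expected to give about 8000 nM, in a range from 3000 nM to 20000 nM.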

Compound 3, half-maximal inhibitory concentration: 8010 nM
Beside the measured number, compound 3's estimate is 1.0-fold (0.00 log units) below it; measured number inside the range.
By their numbers in this assay, from the lowest: compounds 2, 3 and 1 (each within the scatter of the next).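

Among these compounds, this is the first measured step at this position, on a nitrogen on an aromatic ring: in this assay, 4-ethylphenyl in place of 3-chlorophenyl gives a 1.0-fold higher number from compound 2 to compound 3 (0.01 log units; within the scatter). This single exchange therefore stays within the scatter, although it changes both the group's name and its heavy-atom count, from 7 to 8. Nothing measured here offers an explanation for this result.

As far as these compounds go, it remains open whether an amine or a carboxylic acid on this phenyl ring, or a longer chain in place of the ethyl, would move the number beyond the scatter.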